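Adding two methyls beside the phenol: from compound 3 to compound 4

The compounds below may be only part of what the source reports. "The series", "measured", "known", "first", "only" and "open" are said of these compounds alone.

Measured compounds:
- Compound 1, `CN(C)CCn1cnnc1-c1cc(Oc2ccc(NC(=O)N/N=C/c3cccc(Br)c3)cc2F)ccn1`: 830 nM
- Compound 2, `CN(C)CCn1cnnc1-c1cc(Oc2ccc(NC(=O)N/N=C/c3cc(C(C)(C)C)cc(C(C)(C)C)c3O)cc2F)ccn1`: 520 nM
- Compound 3, `CN(C)CCn1cnnc1-c1cc(Oc2ccc(NC(=O)N/N=C/c3ccc(O)cc3)cc2F)ccn1`: 7750 nM

All three share one core and differ only in the aryl group on a carbon with a double bond to nitrogen. In a functional assay on U-87MG ATCC cells (Homo sapiens) for cytotoxicity, read by MTT assay, with a stated time of 72 h (on this read-out higher numbers stand for weaker inhibition and lower numbers for stronger inhibition), compound 3 gives the highest of the three numbers; compound 1 sits nearest to it with a lower number, and compound 2 lies furthest away with a still lower number. Going by the values given here, the one directly comparable step is a 9.3-fold higher number from compound 1 to compound 3 (0.97 log units; beyond the scatter), where a change of aryl group alone moved the number well beyond the scatter.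

Compound 4, `Cc1cc(/C=N/NC(=O)Nc2ccc(Oc3ccnc(-c4nncn4CCN(C)C)c3)c(F)c2)cc(C)c1O`, has not yet been tested. It differs from compound 3 as follows: 4-hydroxy-3,5-dimethylphenyl in place of 4-hydroxyphenyl on a carbon with a double bond to nitrogen. Compound 4 thus sits between compound 3 and compound 2 in its aryl group. Because compound 2 gives 520 nM while compound 3 gives 7750 nM, a lower number is expected for compound 4 in this assay, but not as low as that of compound 2. Compound 4 is therefore expected to give about 1800 nM, within 600 nM to 5000 nM, an estimated step of a 4.3-fold lower number from compound 3 to compound 4 (0.63 log units; beyond the scatter).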

Compound 4, half-maximal inhibitory concentration: 7710 nM
Estimate against measurement, compound 4: 4.3-fold (0.63 log units) below, and the stated range ends below it.
By their numbers in this assay, from the lowest: compounds 2 and 1 (each within the scatter of the next); then compounds 4 and 3 (each within the scatter of the next).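

In this assay putting two methyl groups on the 4-hydroxyphenyl ring leaves the number within the scatter (a 1.0-fold lower number from compound 3 to compound 4 (0.00 log units; within the scatter)), so this added bulk at the carbon with a double bond to nitrogen brings no measurable gain. The 3-bromophenyl group of compound 1 still gives a clearly lower number than the new group (a 9.3-fold higher number from compound 1 to compound 4 (0.97 log units; beyond the scatter)), and the two added methyls do not bring the number towards that of compound 2 (520 nM). No measurement available here explains this flat step.

Still open, going by these compounds, is what a methoxy group, an amine or a carboxylic acid would do in place of the hydroxyl on this ring. The compounds shown also do not separate the effect of the two tert-butyl groups of compound 2 from that of where its hydroxyl sits.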